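An aryl swap on compound 3

The source may report more compounds than this note shows. Statements on the series, on what has been measured and on what is new or still open speak of the compounds shown alone.

Measured in a functional assay on MDA-MB-231 cells (Homo sapiens) for antiproliferative activity, read by MTT assay, with a stated time of 72 h; on this read-out lower numbers stand for stronger inhibition and higher numbers for weaker inhibition:
Compound 1 `CC(=O)c1ccc(-c2cccc(NC(=O)CCc3ccc4c(c3)B(O)OC4)c2)cc1`: 59000 nM
Compound 2 `CC(=O)c1ccc(-c2cccc(NC(=O)CCc3cccc4c3COB4O)c2)cc1`: 41000 nM
Compound 3 `COc1cccc(-c2cccc(NC(=O)CCc3cccc4c3C(O)OC4)c2)c1`: 52000 nM

Compound 3, at 52000 nM, lies within the usual scatter of both compound 1 and compound 2, so these three cannot be ranked. Compound 4 `CC(=O)c1ccc(-c2cccc(NC(=O)CCc3cccc4c3C(O)OC4)c2)cc1` keeps the core of compound 3 but has 4-acetylphenyl in place of 3-methoxyphenyl on an aromatic carbon. Among the compounds with values here, no measured step makes this swap directly. The nearest evidence is a 1.4-fold lower number from compound 1 to compound 2 (0.16 log units; within the scatter), a small step between two compounds that both carry 4-acetylphenyl. Compound 2 gives 41000 nM with that group, which is within the scatter of the value for compound 3. No step beyond the scatter is therefore expected in this assay. The estimated step is a 1.1-fold lower number from compound 3 to compound 4 (0.04 log units; within the scatter). Compound 4 is expected at 47000 nM, with an estimated range of 24000 nM to 90000 nM.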

Compound 4, half-maximal inhibitory concentration: 29000 nM
Beside the measured number, compound 4's estimate is 1.6-fold (0.21 log units) above it, and the stated range covers the measured number.
By their numbers in this assay, from the lowest: compounds 4, 2, 3 and 1 (each within the scatter of the next, the first and the last beyond it).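

In this assay, within the data shown here, the first direct comparison at this aromatic carbon cannot separate 4-acetylphenyl from 3-methoxyphenyl (a 1.8-fold lower number from compound 3 to compound 4 (0.25 log units; within the scatter)). With 4-acetylphenyl held fixed, changing the group on the saturated chain carbon gives one step within the scatter (a 1.4-fold lower number from compound 2 to compound 4 (0.15 log units; within the scatter)) and one modest step beyond it (a 2.0-fold lower number from compound 1 to compound 4 (0.31 log units; beyond the scatter)). No measurement here explains these results. Going by these compounds, whether an amine or a carboxylic acid on the phenyl ring would give a clearer step remains open. So does the effect of a longer chain leading to the amide carbonyl.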